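The source may report more compounds than this note shows. Statements on the series, on what has been measured and on what is new or still open speak of the compounds shown alone.

Measured compounds in a functional assay on MV4-11 cells (Homo sapiens) for cytotoxicity, read by colorimetric assay and MTT assay, with a stated time of 3 days, tested at 20 uM; a lower number here means a stronger effect, a higher number a weaker effect of the compound at the concentration tested:
compound 1 `Cc1ccccc1-n1cc(-c2ccccc2)c(-c2ccc3c(c2)NC(=O)CO3)n1`: 54.2%
compound 2 `O=C1COc2ccc(-c3nn(-c4ccc(Cl)cc4)cc3-c3ccccc3)cc2N1`: 91.9%
compound 3 `O=C1COc2ccc(-c3[nH]c(-c4c[nH]c5ncccc45)nc3-c3ccccc3)cc2N1`: 8.9%

Compound 3 gives the lowest number of the three in this assay; its value lies below those of compound 1 and compound 2 by more than the scatter, so it has the strongest effect in this set. Compound 4 `O=C1COc2ccc(-c3[nH]c(-c4ccc(Cl)cc4Cl)nc3-c3ccccc3)cc2N1` is not yet measured. It differs from compound 3 in one place: a group of 8 heavy atoms (6 carbon, 2 chlorine; one six-membered aromatic ring of carbon only) in place of a group of 9 heavy atoms (7 carbon, 2 nitrogen; one five-membered aromatic ring with 1 hetero atom, one six-membered aromatic ring with 1 hetero atom), on an aromatic carbon. Among the measured compounds shown here, the only measured step is a number 37.7 percentage points higher from compound 1 to compound 2 (beyond the scatter). That step also exchanges one ring group for another, though on a ring nitrogen rather than on the ring carbon concerned here, and it shows that such an exchange alone can move the number a long way. For the measured compounds named here, no measured step removes the group that leaves here. Compounds 1 and 2, which have no group corresponding to the one that leaves, both give higher numbers than compound 3. A rise in the number is therefore expected for compound 4, estimated as a number 51.1 percentage points higher from compound 3 to compound 4 (beyond the scatter). Compound 4 is estimated at 60% in this assay, with a range from 30% to 90%.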

Compound 4, a percentage reported as activity, at one concentration (the size of the read-out at that concentration, not a potency): 41.1%
Estimate against measurement, compound 4: 18.9 percentage points above, and the stated range covers the measured number.
By their numbers in this assay, from the lowest: compound 3; then compound 4; then compound 1; then compound 2.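

The aromatic carbon between two ring nitrogen atoms proves sensitive to what it carries: in this assay, 2,4-dichlorophenyl in place of the group with one five-membered and one six-membered aromatic ring gives a number 32.2 percentage points higher from compound 3 to compound 4 (beyond the scatter) on the shared core. Among the compounds shown here, until now, no measured pair had varied this carbon, so this is the first direct reading of a change there. The exchange removes the hydrogen-bond donor and acceptor counted on the leaving group and introduces two chlorine atoms in one step, so the compounds shown cannot divide the change among these features.

Still open, as far as these compounds go, is how this carbon responds to a simple phenyl, an amine or a carboxylic acid in place of these two ring groups. The data shown offer no explanation for the size of the step.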